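The source may hold more compounds than are shown below. What is called first, only, known or untested is meant among the compounds shown, and "the series" means these compounds.

Measured so far in a functional assay on MCF7 cells (Homo sapiens) for antiproliferative activity, read by sulforhodamine B assay, with a stated time of 3 days; a higher number here means a weaker inhibitor, a lower number a stronger inhibitor:
- compound 1 `c1nc(OCC2CCCCC2)c2nc[nH]c2n1`: 32300 nM
- compound 2 `c1ccc2c(c1)COC(n1cnc3c(OCC4CCCCC4)ncnc31)CO2`: 11600 nM

Compound 2, at 11600 nM, holds the lower of the two numbers. Compound 1, at 32300 nM, holds the higher, and the gap between them lies beyond the usual scatter. Both numbers sit in a weak range for this assay.

The next compound to be read is compound 3 `C=CCOc1ncnc2c1ncn2C1COc2ccccc2CO1`. Its difference from compound 2 is vinyl in place of cyclohexyl on a saturated chain carbon bound to an oxygen on an aromatic ring, which can also be read as cyclohexylmethoxy to allyloxy. Among the compounds with values here, no measured pair shows this change, so the expectation is only loosely grounded. Within the data shown here, the two values above are the sole guide to scale.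

A small rise in the number is expected in this assay, close to the edge of the scatter, meaning a slightly weaker inhibitor. The expected move is a 1.8-fold higher number from compound 2 to compound 3 (0.26 log units; within the scatter). For compound 3 the estimate is 21000 nM, with an expected range of 8000 nM to 55000 nM.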

Compound 3, half-maximal inhibitory concentration: 5040 nM
Compound 3: the middle estimate sits 4.2-fold (0.62 log units) above what was measured, and the stated range ends above it.
By their numbers in this assay, from the lowest: compound 3; then compound 2; then compound 1.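

In this assay, cutting the cyclohexylmethoxy group of compound 2 down to allyloxy does not cost activity: vinyl in place of cyclohexyl on a saturated chain carbon bound to an oxygen on an aromatic ring gives a modest step beyond the scatter (a 2.3-fold lower number from compound 2 to compound 3 (0.36 log units; beyond the scatter)). The earlier compounds shown here both carried cyclohexylmethoxy and could say nothing about this position, whereas this pair shows that the six-membered carbon ring is not needed here for the activity read in this cell assay. Nothing available accounts for the direction of this step.

A single step cannot separate the loss of the ring from the arrival of the double bond, and a saturated propoxy group in the same place would be needed to tell these two apart. Also open, as far as these compounds go, is how far the trend runs, since a benzyloxy group, a longer chain or a chain ending in an amine could each move the number either way, and even the better value here remains a single reading in a weak range.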